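This account rests on a few compounds, and the source may have more. Where it says the series, first, only, none or still open, it means among the compounds named here.

Measured in a functional assay on HCT-15 cells (Homo sapiens) for inhibition, read by sulforhodamine B assay; a lower number here means a stronger inhibitor of growth, a higher number a weaker inhibitor of growth:
- compound 1 `COc1cccc(CN2CCC=C(CCC(=O)NO)C2=O)c1`: 9030 nM
- compound 2 `O=C(CCC1=CCCN(Cc2ccc3ccccc3c2)C1=O)NO`: "not determined" (no result reported)
- compound 3 `O=C(CCC1=CCCN(CCCc2ccc(-c3ccccc3)cc2)C1=O)NO`: 3190 nM

Only two of these entries carry a number, as compound 2 has no result. Of those two, compound 1 stands highest at 9030 nM, making it the weaker growth inhibitor. Compound 3 reads lower at 3190 nM, a gap beyond the usual scatter.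

The next compound to be tested is compound 4 `Cc1cccc(CN2CCC=C(CCC(=O)NO)C2=O)c1`. It differs from compound 1 in a single place: methyl in place of methoxy on an aromatic carbon. Methyl takes the place of methoxy on an aromatic carbon, and the rest of the structure is unchanged. Within the data shown here, no measured pair covers this swap, or any other single change, so the data give no direct guide to its size. The expectation therefore starts from compound 1 at 9030 nM, with no direction strongly favoured in this assay. An estimated shift of a 1.1-fold lower number from compound 1 to compound 4 (0.05 log units; within the scatter) is expected, which would stay within the scatter. For compound 4 the estimated value is 8000 nM, with an expected range of 3500 nM to 18000 nM.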

Compound 4, concentration for 50% growth inhibition: > 10000 nM
Compound 4 ended at the assay's limit; the forecaster's own chance of this, stated with the estimate: 5%; middle value at least 1.2-fold (0.09 log units) from the limit.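

In this assay, compound 4 gives > 10000 nM, which is a limit of the assay and not a number. Methyl in place of methoxy on the aromatic carbon, meta to a large group, gives the first single-place step in the series, an at least 1.1-fold higher number from compound 1 to compound 4 (0.04 log units; that floor lies within the scatter), so this swap shows no gain in growth inhibition over compound 1, though its floor does not establish a real loss. The full size of the step cannot be read because the read-out stops at a limit: the limit of > 10000 nM in this assay, at which 1 of the 4 values shown sits.

The compounds shown leave open how a hydroxyl, a chlorine or an amine on this same aromatic carbon would read in this assay. They also leave open how the ring would read with only hydrogen at this carbon, which would give methoxy and methyl a common reference.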